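The source may hold more compounds than are shown below. What is called first, only, known or untested is meant among the compounds shown, and "the series" means these compounds.

- Compound 1 `Cn1nccc1-c1cnc(NCc2c(F)ccc3c2CCO3)c2cn[nH]c(=O)c12` gives 2.6 in a physicochemical assay for lipophilicity, using the shake flask method, in phosphate buffer, measured as octanol-water partition, with a stated time of 30 min, at pH 7.4; a higher number here means a more lipophilic compound, a lower number a more polar compound
- Compound 2 `Cc1ncc(-c2cnc(NCc3c(F)ccc4c3CCO4)c3cn[nH]c(=O)c23)n1C` gives 1.9 in this assay

Compound 2 holds the lower of the two numbers, beyond the scatter. Compound 3 `Cc1cc(-c2cnc(NCc3c(F)ccc4c3CCO4)c3cn[nH]c(=O)c23)n(C)n1` has the same atoms joined differently, with 1,3-dimethyl-1H-pyrazol-5-yl in place of 1,2-dimethyl-1H-imidazol-5-yl on an aromatic carbon. For the measured compounds named here, the only measured step bearing on this is a number 0.70 log units lower from compound 1 to compound 2 (beyond the scatter) and it exchanged 1-methyl-1H-pyrazol-5-yl for 1,2-dimethyl-1H-imidazol-5-yl. Compound 3 carries a pyrazolyl group again, so a rise of similar size, beyond the scatter, is expected in this assay (estimated as a number 0.90 log units higher from compound 2 to compound 3 (beyond the scatter)). The estimate for compound 3 is 2.8 and a measurement is expected between 2.4 and 3.2 as its range.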

Compound 3, distribution coefficient: 3
Compound 3: the middle estimate sits 0.20 log units below what was measured; the range from low to high includes it.
By their numbers in this assay, from the lowest: compound 2; then compound 1; then compound 3.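

Swapping 1,2-dimethyl-1H-imidazol-5-yl for 1,3-dimethyl-1H-pyrazol-5-yl on this aromatic carbon gives a number 1.10 log units higher from compound 2 to compound 3 (beyond the scatter) in this assay, so the arrangement of the same atoms in the group matters here, even though the counted atoms, donors and acceptors stay identical. Adding a single methyl in place of hydrogen on the pyrazolyl ring gives a number 0.40 log units higher from compound 1 to compound 3 (beyond the scatter) and is a modest step. No measurement here gives a reason for either step.

Still open, from the compounds shown here alone, is how an amine or a carboxylic acid on this ring would shift the number. Going by these compounds, a longer chain such as ethyl in place of the added methyl is equally open.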